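The source may report more compounds than this note shows. Statements on the series, on what has been measured and on what is new or still open speak of the compounds shown alone.

Measured compounds:
compound 1 `COc1ccc(-c2cc3ccccc3nc2/C=C/C(=O)c2ccc(O)cc2)cc1` gives 6350 nM
compound 2 `COc1ccc(-c2cc3ccccc3nc2/C=C/C(=O)c2ccc([N+](=O)[O-])cc2)cc1` gives 840 nM
compound 3 `COc1ccc(-c2cc3ccccc3nc2/C=C/C(=O)c2ccc[nH]2)cc1` gives > 10000 nM

In a functional assay on MDA-MB-231 cells (Homo sapiens) for antiproliferative activity, read by XTT assay, with a stated time of 72 h (on this read-out lower numbers stand for stronger inhibition and higher numbers for weaker inhibition), compound 1 gives 6350 nM and compound 2 gives 840 nM. For compound 3 this assay reports only a limit, > 10000 nM, and no number. So compound 3 stands at the weak end of the three, at the limit of > 10000 nM in this assay, at which 1 of the 3 values shown sits. The two steps that lead to it are an at least 1.5-fold higher number from compound 1 to compound 3 (0.19 log units; that floor lies within the scatter) and an at least 11-fold higher number from compound 2 to compound 3 (1.07 log units; beyond the scatter); read the other way, both say that an aryl group on the carbonyl carbon gives a lower number than the 1H-pyrrol-2-yl group, clearly so against compound 2 and only within the scatter against compound 1.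

Compound 4 `COc1ccc(-c2cc3ccccc3nc2/C=C/C(=O)c2cnc(N)nc2C)cc1` differs from compound 3 by 2-amino-4-methylpyrimidin-5-yl in place of 1H-pyrrol-2-yl on a carbonyl carbon. As compound 1 and compound 2 show, a six-membered aromatic ring on that carbonyl carbon has so far gone with lower numbers than the five-membered one, so in this assay a step downward is expected for compound 4, of the size an at least 2.5-fold lower number from compound 3 to compound 4 (0.39 log units; beyond the scatter). Since compound 3 is only a limit, the size of that step is uncertain. Compound 4 is therefore estimated at 4000 nM, with a range from 800 nM to 20000 nM.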

Compound 4, half-maximal inhibitory concentration: > 10000 nM
Compound 4: only a limit was reported; the forecaster's own chance of this, stated with the estimate: 30%; middle value at least 2.5-fold (0.39 log units) away from the limit.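

The 2-amino-4-methylpyrimidin-5-yl group shows that a six-membered aromatic ring on this carbonyl carbon does not by itself go with a lower number: in this assay compound 4 gives only a limit, > 10000 nM. Against the 4-nitrophenyl group, the change gives an at least 11-fold higher number from compound 2 to compound 4 (1.07 log units; beyond the scatter), whereas against the 4-hydroxyphenyl group it gives an at least 1.5-fold higher number from compound 1 to compound 4 (0.19 log units; that floor lies within the scatter), so only the first of these comparisons is clearly beyond the scatter. The step from compound 3 to compound 4 cannot be read, and the five-membered and the new six-membered ring now stand at the same limit: the limit of > 10000 nM in this assay, at which 2 of the 4 values shown sit.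

As far as these compounds go, how far past that limit either compound lies stays open, so the 1H-pyrrol-2-yl and 2-amino-4-methylpyrimidin-5-yl groups cannot be ranked against each other. Also open, from the compounds shown here alone, is what the lower number of compound 2 depends on, and whether a phenyl ring carrying an amine or a carboxylic acid in place of the nitro group, or the pyrimidine ring without its amine or its methyl, would give a readable value in this assay.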